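The compounds below may be only part of what the source reports. "The series", "measured", "known", "first", "only" and "open" are said of these compounds alone.

In an ADME assay on Vero cells (Chlorocebus sabaeus) for cytotoxicity, read by MTT assay, with a stated time of 72 h (a higher number here means that more compound is tolerated, a lower number that less compound is tolerated), compound 2 `CCOC(=O)c1c(-c2ccc(OC)cc2)oc2ccc(OCCCCCCN3C(=O)/C(=N\OC)c4ccccc43)cc12` gives 32 ug/mL, within the scatter of both compound 1 `CCOC(=O)c1c(-c2ccc(OC)cc2)oc2ccc(OCCCCCCN3C(=O)/C(=N\OC)c4cc(F)ccc43)cc12` at 16 ug/mL and compound 3 `CCOC(=O)c1c(-c2ccccc2)oc2ccc(OCCCN3C(=O)/C(=N\OC)c4ccccc43)cc12` at 64 ug/mL. Compound 4 `CCO/N=C1\C(=O)N(CCCCCCOc2ccc3oc(-c4ccc(OC)cc4)c(C(=O)OCC)c3c2)c2ccccc21` differs from compound 2 in one place, methyl in place of hydrogen on a saturated chain carbon bound to an oxygen on an unsaturated carbon, which also reads methoxy to ethoxy. Within the data shown here, no measured step covers this change. Among the measured compounds shown here, the only single-place step, a 2.0-fold higher number from compound 1 to compound 2 (0.30 log units; within the scatter), is a different change, hydrogen in place of fluoro on an aromatic carbon, and it stays within the scatter. No shift beyond the scatter is therefore expected. The estimate for compound 4 is 32 ug/mL, with an expected range of 16 ug/mL to 64 ug/mL. This estimate means an expected no change at the digits printed from compound 2 to compound 4 (within the scatter).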

Compound 4, half-maximal cytotoxic concentration: 16 ug/mL
Beside the measured number, compound 4's estimate is 2.0-fold (0.30 log units) above it; the range from low to high includes it.
By their numbers in this assay, from the lowest: compounds 1, 4, 2 and 3 (each within the scatter of the next, the first and the last beyond it).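

Methoxy to ethoxy at this position gives a 2.0-fold lower number from compound 2 to compound 4 (0.30 log units; within the scatter) in this assay. Among these compounds, this pair is the only reading of the change, and it shows that methyl in place of hydrogen on a saturated chain carbon bound to an oxygen on an unsaturated carbon stays within the scatter. No supporting data bear on this step.

On these data alone, whether a longer chain, such as propoxy or benzyloxy, or a terminal amine at this place would also stay within the scatter remains open. Also open, as far as these compounds go, is whether methoxy to ethoxy reads the same on the fluoro-bearing core of compound 1.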